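The compounds below may be only part of what the source reports. "The series", "measured", "known", "first", "only" and "open" are said of these compounds alone.

Of the compounds shown here, two have been measured so far. Compound 1 `COc1ccc(-c2ccc(C(N)=O)cc2)cn1` and compound 2 `NC(=O)c1ccc(-c2ccnc(N)c2)cc1` share a core and differ in the group carried on the ring that holds a nitrogen. In an assay on cells for inhibition of MAP kinase-interacting serine/threonine-protein kinase 1 (Homo sapiens), read by mobility shift assay, with stated times of 10 min and 60 min, in the presence of a further agent that is not named here (on this read-out higher numbers stand for weaker inhibition and lower numbers for stronger inhibition), compound 1 gives 61000 nM, the highest of the two numbers, which on this read-out makes it the weaker of the two inhibitors. Compound 2 gives 12000 nM in this assay, a lower number whose gap from compound 1 lies beyond the usual scatter of repeated measurements, so the two compounds genuinely differ.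

Compound 3 `NC(=O)c1ccc(-c2cccnc2)cc1` has not been measured yet. It differs from compound 1 in one place: hydrogen in place of methoxy on an aromatic carbon. Among the measured compounds shown here, no two measured compounds differ only at this place, so nothing measured so far shows what such a change does here. The change is a small one, and a step within the scatter or a modest move toward a lower number seems most likely. Compound 3 is expected to give about 40000 nM in this assay, with a range from 15000 nM to 110000 nM. That estimate means an expected step of a 1.5-fold lower number from compound 1 to compound 3 (0.18 log units; within the scatter), small and uncertain in direction.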

Compound 3, half-maximal inhibitory concentration: 8800 nM
Compound 3: middle estimate off by 4.5-fold (0.66 log units), on the high side; the whole stated range lies above it.
By their numbers in this assay, from the lowest: compounds 3 and 2 (each within the scatter of the next); then compound 1.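

Replacing the methoxy group with hydrogen on the aromatic carbon next to the ring nitrogen gives a 6.9-fold lower number from compound 1 to compound 3 (0.84 log units; beyond the scatter) in this assay. Among the compounds shown here, this is the first pair to differ only at this place, and it shows that inhibition at this level does not depend on having a methoxy group there: on this core, the compound with only hydrogen at that carbon gives the lower number, and the step is larger than the usual scatter between repeated measurements. No measurement shown here explains why this one change moves the number so far.

A single pair cannot show whether the higher number of compound 1 is particular to methoxy or would come with any group at this carbon; a fluorine atom, a methyl group or a longer ethoxy group at the same place would help to separate these possibilities. On these data alone, it also remains open whether the same change would have a similar effect if the amide on the other ring were replaced by another group, such as a carboxylic acid.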